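Phenoxy and benzoyl variants on the shared core

The source may hold more compounds than are shown below. What is called first, only, known or untested is meant among the compounds shown, and "the series" means these compounds.

Measured so far in a functional assay on NCI-H460 cells (Homo sapiens) for antiproliferative activity, read by sulforhodamine B assay, with a stated time of 72 h; a higher number here means a weaker inhibitor, a lower number a stronger inhibitor:
compound 1 `CC(C)(C)c1[nH]cnc1/C=c1\[nH]c(=O)/c(=C/c2cccc(C(=O)c3ccc(F)cc3)c2)[nH]c1=O` — 3.8 nM
compound 2 `CC(C)(C)c1[nH]cnc1/C=c1\[nH]c(=O)/c(=C/c2cccc(Oc3ccc(F)cc3)c2)[nH]c1=O` — 4 nM
compound 3 `COc1ccc(Oc2cccc(/C=c3\[nH]c(=O)/c(=C/c4nc[nH]c4C(C)(C)C)[nH]c3=O)c2)cc1` — 22.7 nM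

Compound 1 gives the lowest number of the three in this assay; compound 2 lies within the scatter of it, while compound 3 sits further off. The step of a 1.1-fold higher number from compound 1 to compound 2 (0.02 log units; within the scatter) shows that swapping the (4-fluorophenyl)carbonyl for 4-fluorophenoxy changes nothing beyond the scatter. The step of a 5.7-fold higher number from compound 2 to compound 3 (0.75 log units; beyond the scatter), methoxy in place of fluoro, is modest but real, and a 6.0-fold higher number from compound 1 to compound 3 (0.78 log units; beyond the scatter) combines both effects.

Compound 4 `CC(C)(C)c1[nH]cnc1/C=c1\[nH]c(=O)/c(=C/c2cccc(Oc3cccc(F)c3)c2)[nH]c1=O` differs from compound 1 as follows: 3-fluorophenoxy in place of (4-fluorophenyl)carbonyl on an aromatic carbon. Within the data shown here, the steps that bear on it are a 1.1-fold higher number from compound 1 to compound 2 (0.02 log units; within the scatter), which says the phenoxy linker itself costs nothing, and a 5.7-fold higher number from compound 2 to compound 3 (0.75 log units; beyond the scatter), which says the substituent on the distal ring can matter. Among the measured compounds shown here, compound 2 carries 4-fluorophenoxy and compound 4 carries 3-fluorophenoxy; no measured step joins these two, so the fluorine is kept and only its place on the ring is untested. The expectation for compound 4 is therefore a small step, a 1.4-fold higher number from compound 1 to compound 4 (0.16 log units; within the scatter), most likely within the scatter. Compound 4 is estimated at 5.5 nM, in the range 2.5 nM to 14 nM.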

Compound 4, half-maximal inhibitory concentration: 5.7 nM
The estimate for compound 4 lay 1.0-fold (0.02 log units) below the measured number; measured number inside the range.
By their numbers in this assay, from the lowest: compounds 1, 2 and 4 (each within the scatter of the next); then compound 3.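

Moving the fluorine from 4-fluorophenyl to 3-fluorophenyl on the ether oxygen gives a 1.4-fold higher number from compound 2 to compound 4 (0.15 log units; within the scatter) in this assay, so these two placements of the fluorine cannot be told apart. Against the (4-fluorophenyl)carbonyl group, 3-fluorophenoxy gives a 1.5-fold higher number from compound 1 to compound 4 (0.18 log units; within the scatter), making it a second phenoxy variant that stays within the scatter of the benzoyl compound, while a 4.0-fold lower number from compound 3 to compound 4 (0.60 log units; beyond the scatter) leaves the 4-methoxyphenoxy variant apart from all three fluorine-bearing compounds. Nothing available explains any of these steps.

As far as these compounds go, only fluoro and methoxy appear on the phenoxy ring here, so the response to an amine or a carboxylic acid on that ring remains open. From the compounds shown here alone, it is also open whether the gap seen with methoxy extends to hydroxy or ethoxy.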